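Series notes: substituent exchange on the aromatic carbon

The source may report more compounds than this note shows. Statements on the series, on what has been measured and on what is new or still open speak of the compounds shown alone.

Measured so far:
compound 1, `CCS(=O)(=O)Nc1cc(F)cc2c1CCCC2c1c[nH]cn1`, 3630 nM
compound 2, `CCS(=O)(=O)Nc1cc(Cl)cc2c1CCCC2c1c[nH]cn1`, 363 nM

Compound 2 gives the lowest of the two numbers in an assay on isolated protein for binding affinity to Alpha-1D adrenergic receptor (Rattus norvegicus), read by radioligand binding; a higher number here means a weaker inhibitor, a lower number a stronger inhibitor; the nearest is compound 1, 3630 nM, a step away that lies beyond the scatter. Among the compounds with values here, the only measured step, a 10-fold lower number from compound 1 to compound 2 (1.00 log units; beyond the scatter), is the sole guide to the substituent at this position.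

Compound 3, `CCS(=O)(=O)Nc1cc(C2CCCCC2)cc2c1CCCC2c1c[nH]cn1`, is not yet measured. It differs from compound 2 by cyclohexyl in place of chloro on an aromatic carbon. Within the data shown here, no measured pair shows a cyclohexyl group here, so the step from compound 1 to compound 2 bears on it only loosely: it indicates the position tolerates exchange and that the number moved by a modest amount when chloro replaced fluoro. Whether the much larger cyclohexyl group continues that direction cannot be read from two compounds.

Compound 3 is therefore expected near 250 nM, within 40 nM to 2000 nM, which means an estimated step of a 1.5-fold lower number from compound 2 to compound 3 (0.16 log units; within the scatter), with a wide range on both sides.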

Compound 3, inhibition constant: 447 nM
Estimate against measurement, compound 3: 1.8-fold (0.25 log units) below; the range from low to high includes it.
By their numbers in this assay, from the lowest: compounds 2 and 3 (each within the scatter of the next); then compound 1.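

In this assay, cyclohexyl, with its six heavy atoms and non-aromatic ring, replaces the single chlorine atom on the aromatic carbon with a 1.2-fold higher number from compound 2 to compound 3 (0.09 log units; within the scatter) and so cannot be told apart from chloro at this position. The fluoro compound stays separate from both, with an 8.1-fold lower number from compound 1 to compound 3 (0.91 log units; beyond the scatter) alongside the earlier chloro step, so the position tolerates a far bulkier carbon ring without the number returning to the level of compound 1. No supporting measurement bears on why these three groups fall as they do.

Open, as far as these compounds go, is whether groups carrying hydrogen-bond donors or acceptors, such as an amine, a hydroxyl or a carboxylic acid, stay level with chloro and cyclohexyl. Also open, from the compounds shown here alone, is whether a flat ring such as phenyl, or a smaller one such as cyclopropyl, does the same.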